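A few compounds are considered here, and "the series" means these few. Any claim that something is new, unique, unknown or untested is made for them only; others in the source may bear on it.

Measured compounds:
compound 1, `N/C(=N\NC(=S)N1CCCCCC1)c1ccccn1`, in a functional assay on A-375 cells (Homo sapiens) for cytotoxicity, read by MTT assay, with a stated time of 72 h, tested at 30 uM (on this read-out lower numbers stand for less inhibition of growth and higher numbers for more inhibition of growth at the one concentration tested), gives 90%.
compound 2, `Cc1cccc(/C(N)=N/NC(=S)N2CCCCCC2)n1`, in this assay gives 70.3%.

Going by the values given here, compound 1 holds the higher of the two numbers; the only other measured compound, compound 2, lies a number 19.7 percentage points lower from compound 1 to compound 2 (beyond the scatter), a change brought about by a methyl in place of hydrogen on an aromatic carbon of the shared core. The unmeasured compound 3, `N/C(=N\NC(=S)N1CCCCCC1)c1ccc(F)cn1`, differs from compound 1 by fluoro in place of hydrogen on an aromatic carbon. Among the compounds with values here, no measured pair shows this particular exchange, so the only guidance comes from the methyl step, which shows that a single small group on the aromatic ring of the core can lower the number modestly. Fluoro is a smaller group than methyl and sits at a different carbon, so a smaller effect is expected. Compound 3 is therefore estimated at 82%, within 65% to 95%, meaning an expected a number 8 percentage points lower from compound 1 to compound 3 (within the scatter) that may not exceed the scatter.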

Compound 3, percent growth inhibition at one concentration: 80%
Beside the measured number, compound 3's estimate is 2 percentage points above it, within the range that was stated.
By their numbers in this assay, from the lowest: compounds 2, 3 and 1 (each within the scatter of the next, the first and the last beyond it).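

In this assay, putting fluoro on this aromatic carbon, two atoms from the ring nitrogen and para to a large group, gives a number 10 percentage points lower from compound 1 to compound 3 (within the scatter) and so leaves the number indistinguishable from that of the unsubstituted core. The earlier methyl change, which gave a number 19.7 percentage points lower from compound 1 to compound 2 (beyond the scatter) at a different carbon, therefore does not hold for every small group on this ring, although these two steps differ in both group and place and cannot separate the two. Nothing measured here explains why fluoro at this carbon leaves the number within the scatter.

From the compounds shown here alone, whether a larger group at this same carbon, such as methoxy or an amine, would also keep the number remains open. So does whether fluoro at the carbon that carries methyl in compound 2 would behave as it does in compound 3.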